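This account rests on a few compounds, and the source may have more. Where it says the series, first, only, none or still open, it means among the compounds named here.

Working notes on the series in a functional assay on CEM-SS cells (Homo sapiens) for cytotoxicity; a lower number here means a stronger inhibitor, a higher number a weaker inhibitor. Compound 1 `Cc1cccc(Cn2c(Cl)nc3cc(Cl)c(Cl)cc32)c1` reads > 100000 nM, which is a limit and not a number. Compound 2 `Clc1cccc(Cn2c(Br)nc3cc(Cl)c(Cl)cc32)c1` reads > 100000 nM, which is also a limit and not a number. Compound 2 therefore has no measured value to place it, and no order can be drawn between the two compounds.

Compound 3 `Cc1cccc(Cn2c(Br)nc3cc(Cl)c(Cl)cc32)c1` differs from compound 2 in one place, with methyl in place of chloro on an aromatic carbon. In this assay no step beyond the scatter is expected, in either direction, because of the limit of > 100000 nM in this assay, at which 2 of the 2 values shown sit. The estimated change is a number no higher from compound 2 to compound 3 (the limit leaves the size open), and a further limit reading is the expected outcome. For compound 3 the estimate is 100000 nM, with an expected range from 40000 nM to 200000 nM.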

Compound 3, half-maximal inhibitory concentration: > 100000 nM
Compound 3 ended at the assay's limit (the forecaster's own chance of this, stated with the estimate: 85%); the middle value lies on the limit itself.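

No new step can be read between compound 1, compound 2 and compound 3 in this assay, because all three readings are limits and not numbers: the limit of > 100000 nM in this assay, at which 3 of the 3 values shown sit.

The compounds shown leave open how these three rank against one another, and which change to the shared core, if any, would give a numerical reading.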